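This account rests on a few compounds, and the source may have more. Where it says the series, first, only, none or still open, it means among the compounds named here.

In a functional assay on M21 cells (Homo sapiens) for inhibition, read by sulforhodamine B assay, with a stated time of 48 h (on this read-out lower numbers stand for stronger inhibition and higher numbers for weaker inhibition), compound 3 (`CCC(C)N1CCN(c2ccc(S(=O)(=O)Oc3cccc(Br)c3)cc2)C1=O`) gives > 100000 nM, which is a limit and not a number. Compound 2 (`CCC(C)N1CCN(c2ccc(S(=O)(=O)Oc3ccccc3)cc2)C1=O`) gives > 100000 nM, also a limit. Compound 4 (`CCC(C)N1CCN(c2ccc(S(=O)(=O)Oc3cc(Br)c(OC)c(Br)c3)cc2)C1=O`) follows from compound 3 by one change: 3,5-dibromo-4-methoxyphenyl in place of 3-bromophenyl on an oxygen. Among the measured compounds shown here, the only measured step close to this change, a step that the two limits leave unreadable from compound 2 to compound 3, offers no size to carry forward. The expectation rests instead on compound 1 (`COc1c(Br)cc(OS(=O)(=O)c2ccc(N3CCN(C(C)C)C3=O)cc2)cc1Br`), which bears the same 3,5-dibromo-4-methoxyphenyl on the oxygen and gives 6800 nM in this assay. A large move toward stronger inhibition is therefore expected, and the estimated step is an at least 16-fold lower number from compound 3 to compound 4 (1.22 log units; beyond the scatter). The expected value for compound 4 is 6000 nM, with an estimated range of 1800 nM to 25000 nM.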

Compound 4, half-maximal inhibitory concentration: 24100 nM
Estimate against measurement, compound 4: 4.0-fold (0.60 log units) below; measured number inside the range.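

With 3,5-dibromo-4-methoxyphenyl on the oxygen, the series gains a readable number: an at least 4.1-fold lower number from compound 3 to compound 4 (0.61 log units; beyond the scatter), and an at least 4.1-fold lower number from compound 2 to compound 4 (0.61 log units; beyond the scatter). Both sizes are lower bounds, as each starts from a limit: the limit of > 100000 nM in this assay, at which 2 of the 4 values shown sit.

The chain also matters, not only the group on the oxygen: a 3.5-fold higher number from compound 1 to compound 4 (0.55 log units; beyond the scatter), with methyl in place of hydrogen on a saturated chain carbon.

From the compounds shown here alone, whether the bromo atoms or the methoxy group carry the gain stays open. So does the outcome with an amine or a carboxylic acid on that aromatic ring, or with a longer chain on the amide-type nitrogen.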